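Removing an ethoxycarbonyl group from the shared core

The source may report more compounds than this note shows. Statements on the series, on what has been measured and on what is new or still open speak of the compounds shown alone.

Measured compounds:
Compound 1 `O=C(O)CCc1cnc(N2CCC(c3nc(COc4ccc(-n5cnnn5)cc4)cs3)CC2)nc1`: "not determined" (no result reported) in a functional assay on cells for agonist activity at Glucose-dependent insulinotropic receptor (Homo sapiens), read by a luciferase reporter, with a stated time of 6 h; on this read-out lower numbers stand for an effect already at smaller amounts and higher numbers for an effect only at larger amounts of compound
Compound 2 `CC(C)(C)OC(=O)N1CCC(c2nc(COc3ccc(-n4cnnn4)cc3)cs2)CC1`: 103 nM
Compound 3 `CCOC(=O)CCc1cnc(N2CCC(c3nc(COc4ccc(-n5cnnn5)cc4)cs3)CC2)nc1`: "not determined" (no result reported) in this assay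

Only compound 2 carries a number in this assay, where compound 2 gives 103 nM; compound 1 and compound 3 have no result, so compound 3 stands nowhere on the numbers shown. Compound 4 `CCc1cnc(N2CCC(c3nc(COc4ccc(-n5cnnn5)cc4)cs3)CC2)nc1` differs from compound 3 in one place: hydrogen in place of ethoxycarbonyl on a saturated chain carbon, two bonds along the chain from an aromatic carbon. Among the measured compounds shown here, no measured step matches this change, so its size and direction remain open; in this assay a shift in either direction beyond the scatter is possible, as is none. For the measured compounds named here, compound 4 is expected to lie near the sole number seen, at about 120 nM, within 20 nM to 800 nM.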

Compound 4, half-maximal effective concentration: 87 nM
Compound 4: middle estimate off by 1.4-fold (0.14 log units), on the high side, and the stated range covers the measured number.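

In this assay the swap of tert-butoxycarbonyl for 5-ethylpyrimidin-2-yl on the amine nitrogen in a ring reads as a 1.2-fold lower number from compound 2 to compound 4 (0.07 log units; within the scatter) and so leaves the number unchanged within the scatter. Compound 3 has no number, so the removal of ethoxycarbonyl cannot be read as a step, and compound 4 only shows that the ethyl chain alone is compatible with a value. Nothing available explains this result.

Still open, going by these compounds, is how the ethyl chain compares with a longer plain alkyl chain, or with one ending in an amine or a primary amide.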